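The source may report more compounds than this note shows. Statements on the series, on what has been measured and on what is new or still open speak of the compounds shown alone.

In a functional assay on the whole organism for inhibition, with Mus musculus as the target, with stated times of 30 min and 2 h, at a dose of 10 mg/kg by the intraperitoneal route (a lower number here means less inhibition, a higher number more inhibition at the dose given (going by the name of the read-out)), three compounds have been examined. Compound 1 `O=C(NCc1ccc(CNS(=O)(=O)c2ccc(F)cc2F)cc1)c1cncnc1` gives 56%, and compound 3 `Cc1nnsc1C(=O)NCc1ccc(CNS(=O)(=O)c2ccc(F)c(F)c2)cc1` gives 54%. Compound 2 `O=C(NCc1ccc(CNS(=O)(=O)c2ccc3c(c2)CCO3)cc1)c1scc2c1OCCO2` gives 0%, the lowest of the three numbers, a gap beyond the scatter to both of the others. Among the measured compounds shown here, no two measured compounds differ in only one place, so no single change can yet be assigned a step. Compound 4 `Cc1cc(C(=O)NCc2ccc(CNS(=O)(=O)c3ccc4c(c3)CCO4)cc2)n(C)n1` is the next candidate; it keeps the sulfonamide side of compound 2 and alters the amide side: a group of 7 heavy atoms (5 carbon, 2 nitrogen; one five-membered aromatic ring with 2 hetero atoms) in place of a group of 9 heavy atoms (6 carbon, 2 oxygen, 1 sulfur; one five-membered aromatic ring with 1 hetero atom, one six-membered non-aromatic ring with 2 hetero atoms), on a carbonyl carbon. Because compound 2 gives 0% while compound 1 and compound 3 carry other heteroaromatic amides and sit higher, an upward step is expected, of moderate size and uncertain. Compound 4 is estimated at 25%, within 0% to 55%, which means an expected step of a number 25 percentage points higher from compound 2 to compound 4 (beyond the scatter) from compound 2 to compound 4 in this assay.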

Compound 4, a percentage reported as inhibition, in the whole organism at one dose (the size of the read-out at that dose, not a potency): 35%
Beside the measured number, compound 4's estimate is 10 percentage points below it; measured number inside the range.
By their numbers in this assay, from the lowest: compound 2; then compound 4; then compounds 3 and 1 (each within the scatter of the next).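

With the sulfonamide side held fixed in this assay, placing 1,3-dimethyl-1H-pyrazol-5-yl on the carbonyl carbon in place of the larger two-ring group gives a step of a number 35 percentage points higher from compound 2 to compound 4 (beyond the scatter). The group on this carbonyl carbon alone can therefore change the reading, and the sulfonamide side of compound 2 does not rule out inhibition. No measurement shown accounts for the step.

Which feature of the exchanged groups matters stays open, as the ring systems and the atom counts change together. On these data alone, how a phenyl ring or a carboxylic acid at this place would read also remains unknown.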